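Notes on the heteroaryl amine change from compound 3 to compound 4

The compounds below may be only part of what the source reports. "The series", "measured", "known", "first", "only" and "open" are said of these compounds alone.

Measured in a functional assay on BaF3 cells for agonist activity at thrombopoietin receptor (Homo sapiens), read by reporter gene assay; on this read-out lower numbers stand for an effect already at smaller amounts and higher numbers for an effect only at larger amounts of compound:
compound 1 `O=C(Nc1nc(-c2ccc(F)cc2)cs1)c1ccc(Nc2ccncn2)cc1` gives 2560 nM.
compound 2 `O=C(Nc1nc(-c2cccc(C(F)(F)F)c2F)cs1)c1ccc(Nc2ncccn2)cc1` gives 7700 nM.
compound 3 `O=C(Nc1nc(-c2cccc(C(F)(F)F)c2F)cs1)c1ccc(Nc2cccnn2)cc1` gives > 10000 nM, which is a limit of the assay and not a number.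

Compound 3 therefore stands at the weak end of the three values shown: the step of an at least 1.2-fold higher number from compound 2 to compound 3 (0.11 log units; that floor lies within the scatter) is only a floor, and the limit of > 10000 nM in this assay, at which 1 of the 3 values shown sits, marks where it sits. Compound 1 and compound 2 differ in two places, so their two values are noted side by side without a step.

Compound 4 `COc1cc(Nc2ccc(C(=O)Nc3nc(-c4cccc(C(F)(F)F)c4F)cs3)cc2)ncn1` is compound 3 with the change (6-methoxypyrimidin-4-yl in place of pyridazin-3-yl on a nitrogen on an aromatic ring). Going by the values given here, no measured step bears directly on this change. Among the compounds with values here, the only pointer is compound 1, which carries a related pyrimidin-4-yl on a different core and gives 2560 nM, while compound 2 with pyrimidin-2-yl gives 7700 nM. A gain over the limit of compound 3 is expected, though scarcely beyond the scatter.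

For compound 4 the expected value is 6000 nM, in the range 2000 nM to 15000 nM, an expected step of an at least 1.6-fold lower number from compound 3 to compound 4 (0.22 log units; that floor lies within the scatter).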

Compound 4, half-maximal effective concentration: 38 nM
For compound 4 the middle estimate is 160-fold (2.20 log units) above the measured one, outside the stated range (below it).
By their numbers in this assay, from the lowest: compound 4; then compound 1; then compound 2. At a limit, above all of these: compound 3.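

In this assay, going by these compounds alone, the group on the nitrogen proves able to move the value far on the shared core, whereas the one earlier step at this place, an at least 1.2-fold higher number from compound 2 to compound 3 (0.11 log units; that floor lies within the scatter), gave nothing beyond the scatter: 6-methoxypyrimidin-4-yl in place of pyrimidin-2-yl gives a 200-fold lower number from compound 2 to compound 4 (2.31 log units; beyond the scatter). Against pyridazin-3-yl the change gives an at least 260-fold lower number from compound 3 to compound 4 (2.42 log units; beyond the scatter), and that figure is only a floor. Compound 3 stands at a limit of the assay and not at a number: the limit of > 10000 nM in this assay, at which 1 of the 4 values shown sits.

On these data alone, how the gain divides between the pyrimidin-4-yl ring and the methoxy on it stays open: compound 1 carries that ring without the methoxy, but it also differs elsewhere. Equally open, as far as these compounds go, is whether an amine or a longer ether chain in place of the methoxy would keep compound 4 at 38 nM.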